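A carboxylic acid replaces chlorine on compound 2

This account rests on a few compounds, and the source may have more. Where it says the series, first, only, none or still open, it means among the compounds named here.

Compound 1 `CCCCCCCCc1ccc(OC(C)C(=O)Cn2nnc(-c3ccc(Cl)cc3)n2)cc1` and compound 2 `CC(Oc1ccc(-c2ccccc2)cc1)C(=O)Cn1nnc(-c2ccc(Cl)cc2)n1` share one core and differ in a single place. In a physicochemical assay for lipophilicity, read by HPLC, tested at 5 mM (a higher number here means a more lipophilic compound, a lower number a more polar compound), compound 1 gives > 8, which is the limit of > 8 in this assay, at which 1 of the 2 values shown sits, and not a number. In this assay, within the data shown here, compound 2 gives 6.1, the only plain number among the two values. The measured change a number at least 1.90 log units lower from compound 1 to compound 2 (beyond the scatter) is a large drop. Compound 3 `CC(Oc1ccc(-c2ccccc2)cc1)C(=O)Cn1nnc(-c2ccc(C(=O)O)cc2)n1` carries carboxy in place of chloro on an aromatic carbon. Among the measured compounds shown here, no measured step matches this change, so the expectation rests on the structures alone. The step of a number 2.10 log units lower from compound 2 to compound 3 (beyond the scatter) is the expected outcome. Compound 3 is estimated at 4, between 3 and 5.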

Compound 3, partition coefficient: 2.6
Compound 3: middle estimate off by 1.40 log units, on the high side; the measured number lies below the stated range.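

Swapping 4-chlorophenyl for 4-carboxyphenyl is the first change shown at this place, since the earlier step exchanged octyl for phenyl elsewhere on the core. In this assay, this swap gives a number 3.50 log units lower from compound 2 to compound 3 (beyond the scatter), so this place, too, can move the reading by a large amount. Nothing measured here gives a reason for the drop.

With only chloro and carboxy shown at this place, it remains open how a methyl ester, a primary amide or an amine would read in this assay.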